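Ethyl to cyclopropyl on the ring nitrogen

The source may report more compounds than this note shows. Statements on the series, on what has been measured and on what is new or still open speak of the compounds shown alone.

Going by the values given here, compound 2 `CCn1c(-c2ccc(OCc3c(-c4c(Cl)cccc4Cl)noc3C(C)C)cc2)nc2ccc(C(=O)O)cc21` gives 2.31 nM in an assay on Huh-7 cells for agonist activity at Bile acid receptor (Homo sapiens), read by a luciferase reporter (on this read-out higher numbers stand for an effect only at larger amounts of compound and lower numbers for an effect already at smaller amounts), the highest of the two numbers measured so far. Among the compounds with values here, its only neighbour is compound 1 `CCC(CC)n1c(-c2ccc(OCc3c(-c4c(Cl)cccc4Cl)noc3C(C)C)cc2)nc2ccc(C(=O)O)cc21`, which in this assay gives 0.8 nM. Within the data shown here, the single step recorded between them, a 2.9-fold higher number from compound 1 to compound 2 (0.46 log units; beyond the scatter), is the one that bears on the change now in question, since both concern the group on the aromatic nitrogen. Compound 3 `CC(C)c1onc(-c2c(Cl)cccc2Cl)c1COc1ccc(-c2nc3ccc(C(=O)O)cc3n2C2CC2)cc1` differs from compound 2 by cyclopropyl in place of ethyl on an aromatic nitrogen. Among the measured compounds shown here, with only one modest step at this position to go on, the number for compound 3 is expected to move by a comparable or smaller amount, and more likely downward, because the one change seen here, a 2.9-fold higher number from compound 1 to compound 2 (0.46 log units; beyond the scatter), raised the number when the larger group was exchanged for ethyl. Compound 3 is therefore expected at 1.5 nM in this assay, within 0.6 nM to 4 nM, a step of a 1.5-fold lower number from compound 2 to compound 3 (0.19 log units; within the scatter) from compound 2.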

Compound 3, half-maximal effective concentration: 16.5 nM
Estimate against measurement, compound 3: 11-fold (1.04 log units) below; the measured number lies above the stated range.
By their numbers in this assay, from the lowest: compound 1; then compound 2; then compound 3.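

In this assay this position proves far less forgiving than the earlier pair suggested: a 7.1-fold higher number from compound 2 to compound 3 (0.85 log units; beyond the scatter) is a larger move than any seen before, and it goes upward, with cyclopropyl adding only one heavy atom to ethyl. Set against the pentan-3-yl group, a 21-fold higher number from compound 1 to compound 3 (1.31 log units; beyond the scatter) makes this the widest step in the series and places cyclopropyl last of the three groups, so the numbers do not follow group size alone, as the earlier step between pentan-3-yl and ethyl might have implied. Nothing available explains why the three-membered ring raises the number.

The compounds shown leave open whether the ring itself or some other feature of cyclopropyl sets it apart. Isopropyl, an open-chain group, and cyclobutyl, a larger ring, on this nitrogen would bear directly on that question.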